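This account rests on a few compounds, and the source may have more. Where it says the series, first, only, none or still open, it means among the compounds named here.

Working notes on the series. Two members have been run in an ADME assay on microsomes from liver (Rattus norvegicus) for metabolic stability (on this read-out higher numbers stand for a longer-lived compound and lower numbers for a shorter-lived compound), so far: compound 1 `Cn1nc2c(=O)n(CC3(O)CCN(Cc4ccc(-c5ccco5)cc4Cl)CC3)cnc2c1-c1ccc(CNCCO)cc1` and compound 2 `Cn1nc2c(=O)n(CC3(O)CCN(Cc4ccc(-c5cccs5)cc4Cl)CC3)cnc2c1-c1ccc(CN)cc1`. In this assay compound 1 gives 1.52 h and compound 2 gives 1.38 h; the two numbers lie within the scatter of each other, so compound 2 cannot be told apart from compound 1 on this read-out. The next member is compound 3 `Cn1nc2c(=O)n(CC3(O)CCN(Cc4ccc(-c5ccc(C(=O)O)o5)cc4Cl)CC3)cnc2c1-c1ccc(CN)cc1`, which differs from compound 2 in one place: 5-carboxyfuran-2-yl in place of thiophen-2-yl on an aromatic carbon. Among the measured compounds shown here, no measured pair isolates this change, so the step cannot be sized from the numbers in hand. For compound 3 a step from compound 2 within the scatter is expected, a 1.1-fold higher number from compound 2 to compound 3 (0.04 log units; within the scatter), in no set direction. Compound 3 is therefore estimated at 1.5 h in this assay, with a range of 0.7 h to 3.2 h.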

Compound 3, half-life: 1.25 h
Estimate against measurement, compound 3: 1.2-fold (0.08 log units) above, within the range that was stated.
By their numbers in this assay, from the lowest: compounds 3, 2 and 1 (each within the scatter of the next).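

In this assay, 5-carboxyfuran-2-yl in place of thiophen-2-yl on this aromatic carbon gives a 1.1-fold lower number from compound 2 to compound 3 (0.04 log units; within the scatter) and so stays within the scatter. Among the compounds shown here, this is the only measured pair that isolates a change at this position, and it shows that the position accepts the larger group, with its added hydrogen-bond donor, without a step that can be told from the scatter. No measurement in hand speaks to a cause of this result. From the compounds shown here alone, the ring and the carboxylic acid enter together, so their separate contributions remain open. A 5-carboxythiophen-2-yl group or a basic amine on the same ring would test this.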